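Cyclic amine replacements on a shared core

The source may report more compounds than this note shows. Statements on the series, on what has been measured and on what is new or still open speak of the compounds shown alone.

compound 1 `COc1cc2c(Nc3ccc(C#N)cc3)ncnc2cc1OCCCN(C)Cc1ccccc1` — > 100000 nM (a limit of the assay)
compound 2 `COc1cc2c(Nc3ccc(C#N)cc3)ncnc2cc1OCCCN1CCCCC1` — 23500 nM
compound 3 `COc1cc2c(Nc3ccc(C#N)cc3)ncnc2cc1OCCCN1CCC(C)CC1` — 32300 nM
compound 4 `COc1cc2c(Nc3ccc(C#N)cc3)ncnc2cc1OCCCN1CCc2ccccc2C1` — not yet measured

In a functional assay on A549 cells (Homo sapiens) for antiproliferative activity, read by MTT assay, with a stated time of 72 h (a higher number here means a weaker inhibitor, a lower number a stronger inhibitor), compound 1 gives > 100000 nM, which is a limit of the assay and not a number. Compound 2 gives 23500 nM in this assay. Compound 3 gives 32300 nM in this assay and stands highest of the two numbers available, with compound 2 nearest: a 1.4-fold higher number from compound 2 to compound 3 (0.14 log units; within the scatter). Closing the open-chain amine of compound 1 into a ring gave an at least 4.2-fold lower number from compound 1 to compound 2 (0.62 log units; beyond the scatter) and an at least 3.0-fold lower number from compound 1 to compound 3 (0.49 log units; beyond the scatter); both sizes are only floors, since compound 1 sits at the limit of > 100000 nM in this assay, at which 1 of the 3 values shown sits.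

Compound 4 differs from compound 3 by 1,2,3,4-tetrahydroisoquinolin-2-yl in place of 4-methylpiperidin-1-yl on a saturated chain carbon, three bonds along the chain from an oxygen on an aromatic ring. The amine stays in a ring, as in compounds 2 and 3, while an aromatic ring returns, as in compound 1. The steps from compound 1 bear on it, but with the amine still cyclic no step beyond the scatter, or at most a small rise, is expected. Compound 4 is therefore expected to give about 40000 nM in this assay, between 15000 nM and 100000 nM. The expected step is a 1.2-fold higher number from compound 3 to compound 4 (0.09 log units; within the scatter).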

Compound 4, half-maximal inhibitory concentration: > 100000 nM
Compound 4: a limit, no number; the forecaster's own chance of this, stated with the estimate: 20%; middle value at least 2.5-fold (0.39 log units) away from the limit.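

In this assay compound 4 gives a limit of the assay, not a number. A cyclic amine on this saturated chain carbon therefore does not by itself give a measurable value: 1,2,3,4-tetrahydroisoquinolin-2-yl gives an at least 3.0-fold higher number from compound 3 to compound 4 (0.49 log units; beyond the scatter) and an at least 4.2-fold higher number from compound 2 to compound 4 (0.62 log units; beyond the scatter), both sizes only floors, and among the compounds shown only those whose amine group carries an aromatic ring, compound 1 and compound 4, lack a number. The step between compound 1 and compound 4 cannot be read, since both sit at the same limit: the limit of > 100000 nM in this assay, at which 2 of the 4 values shown sit.

From the compounds shown here alone, whether the aromatic ring itself sets this result remains open, as two compounds cannot separate it from the larger amine group. Pyrrolidin-1-yl or morpholin-4-yl on the same chain would test how far the values of compound 2 and compound 3 extend across cyclic amines.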